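The compounds below may be only part of what the source reports. "The series", "measured", "known", "first", "only" and "open" are said of these compounds alone.

Among the measured compounds shown here, in an ADME assay on Vero cells (Chlorocebus sabaeus) for cytotoxicity, read by MTT assay, with a stated time of 72 h (on this read-out higher numbers stand for lower toxicity in this test and lower numbers for higher toxicity in this test), compound 2 `COc1c(N2CCN(C/C(C)=N/Nc3ccccc3)C(C)C2)c(F)cc2c(=O)c(C(=O)O)cn(C3CC3)c12` gives 11.1 ug/mL, the only actual number so far. Compound 1 `COC(=O)CCN1CCN(c2c(F)cc3c(=O)c(C(=O)O)cn(C4CC4)c3c2OC)CC1C` reads > 1000 ug/mL, which is a limit of the assay and not a number.

The next structure is compound 3 `COc1c(N2CCN(CC/C(C)=N/Nc3ccccc3)C(C)C2)c(F)cc2c(=O)c(C(=O)O)cn(C3CC3)c12`, which differs on a saturated chain carbon bound to an amine nitrogen in a ring: a group of 11 heavy atoms (9 carbon, 2 nitrogen; one six-membered aromatic ring of carbon only) in place of a group of 10 heavy atoms (8 carbon, 2 nitrogen; one six-membered aromatic ring of carbon only), on a saturated chain carbon bound to an amine nitrogen in a ring. The six-membered aromatic ring of carbon only stays in place.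

For the measured compounds named here, the one measured step that bears on this position is an at least 90-fold lower number from compound 1 to compound 2 (1.95 log units; beyond the scatter). That step is large, and its size is only a bound, since one end of it is the limit of > 1000 ug/mL in this assay, at which 1 of the 2 values shown sits. It also exchanged a group with no ring for one carrying the aromatic ring, a far bigger structural change than the present one. Going by the values given here, it therefore gives little guidance on size here, and no measured step covers so small a change.

In this assay no shift beyond the scatter is expected, and the estimated step is a 1.0-fold lower number from compound 2 to compound 3 (0.00 log units; within the scatter). For compound 3 the expected value is 11 ug/mL, with an estimated range of 4 ug/mL to 35 ug/mL.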

Compound 3, half-maximal cytotoxic concentration: 62.5 ug/mL
Estimate against measurement, compound 3: 5.7-fold (0.75 log units) below, outside the stated range (above it).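

In this assay, the position on a saturated chain carbon bound to an amine nitrogen in a ring proves sensitive to a small change: with the six-membered aromatic ring of carbon only kept, the group of 11 heavy atoms in place of the group of 10 heavy atoms gives a 5.6-fold higher number from compound 2 to compound 3 (0.75 log units; beyond the scatter), a shift toward lower toxicity in this test. Against the group with no ring, the group carrying the aromatic ring still gives an at least 16-fold lower number from compound 1 to compound 3 (1.20 log units; beyond the scatter), so the larger part of the drop first seen with compound 2 survives this change. The size of that step is only a bound, set by a limit for compound 1 and not by a number: the limit of > 1000 ug/mL in this assay, at which 1 of the 3 values shown sits.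

On these data alone, two compounds with an aromatic ring define no trend, so it stays open whether a longer chain would raise the read-out further or reverse the shift. Also open, as far as these compounds go, is whether an amine or a carboxylic acid in place of the six-membered aromatic ring of carbon only would leave the read-out near that of compound 2 and compound 3 or nearer the limit of compound 1.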